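The source may report more compounds than this note shows. Statements on the series, on what has been measured and on what is new or still open speak of the compounds shown alone.

Three measured compounds share one core and differ only in the chains hanging from it. Compound 1 `CCCCCCNc1nc(SCC)nc2ncccc12` gives 1400 nM in a functional assay on MDA-MB-231 cells (Homo sapiens) for cytotoxicity, read by neutral red uptake, with a stated time of 72 h; on this read-out lower numbers stand for stronger inhibition and higher numbers for weaker inhibition. Compound 2 `CCCCCCCNc1nc(SCC)nc2ncccc12` gives 2600 nM in this assay; the change from compound 1 to compound 2 is methyl in place of hydrogen on a saturated chain carbon, six bonds along the chain from a nitrogen on an aromatic ring and the step it made was a 1.9-fold higher number from compound 1 to compound 2 (0.27 log units; within the scatter). Compound 3 `CCCCCNc1nc(SCCCC)nc2ncccc12` gives 6300 nM in this assay, the highest of the three numbers; the difference between the core of compound 3 and the core of compound 1 is not broken down here. Compound 4 `CCCCCCNc1nc(SCCCC)nc2ncccc12` has not been measured. It differs from compound 3 by methyl in place of hydrogen on a saturated chain carbon, five bonds along the chain from a nitrogen on an aromatic ring. Among the compounds with values here, this is the same kind of change as the one from compound 1 to compound 2, but not the same: there the methyl sits six bonds along the chain from a nitrogen on an aromatic ring, here five bonds along the chain from a nitrogen on an aromatic ring. Since a 1.9-fold higher number from compound 1 to compound 2 (0.27 log units; within the scatter) stayed within the scatter, a step of about that size is expected, namely a 1.3-fold higher number from compound 3 to compound 4 (0.10 log units; within the scatter). Compound 4 is therefore estimated at 8000 nM in this assay, with a likely range from 3500 nM to 18000 nM.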

Compound 4, half-maximal inhibitory concentration: 1200 nM
Compound 4: the middle estimate sits 6.7-fold (0.82 log units) above what was measured, outside the stated range (below it).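

Swapping a hydrogen for a methyl on the chain attached through nitrogen does not behave alike on the two cores in this assay, and the two steps differ by more than repeat measurements would explain: the same change on two cores in this assay, a 1.9-fold higher number (0.27 log units; within the scatter) from compound 1 to compound 2 and a 5.3-fold lower number (0.72 log units; beyond the scatter) from compound 3 to compound 4, 9.8-fold (0.99 log units) apart, beyond the scatter of two such steps

The new result, a 5.3-fold lower number from compound 3 to compound 4 (0.72 log units; beyond the scatter), shows that a step that stayed within the scatter on one core cannot be assumed to stay small on another in this series. Adding ethyl on the chain attached through sulfur gives a 1.2-fold lower number from compound 1 to compound 4 (0.07 log units; within the scatter), which leaves compound 1 and compound 4 level within the scatter, but a single pair on each core does not show what lies behind the gap or how general it is.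

The compounds shown leave open how the numbers run over further chain lengths on either core. They also leave open what would happen with a branched chain, or with a chain carrying a hydroxyl group or an amine.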